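The compounds below may be only part of what the source reports. "The series", "measured", "known", "first", "only" and "open" are said of these compounds alone.

Measured compounds in a functional assay on MCF7 cells (Homo sapiens) for cytotoxicity, read by CellTiter-Glo, with a stated time of 5 days; a lower number here means a stronger inhibitor, a higher number a weaker inhibitor:
compound 1 `O=C(O)/C=C/c1ccc(/C(=C(/CCO)c2ccccc2)c2ccc3[nH]ncc3c2)cc1` — > 1000 nM, a limit of the assay rather than a number.
compound 2 `O=C(O)/C=C/c1ccc(/C(=C(\c2ccccc2)C2CCCCC2)c2ccc3[nH]ncc3c2)cc1` — 64 nM.
compound 3 `CC/C(=C(/c1ccc(/C=C/C(=O)O)cc1)c1ccc2[nH]ncc2n1)c1ccccc1` — 33 nM.

Compound 3 has the lowest of the two numbers shown in this assay; its nearest neighbour is compound 2, and the two lie within the usual scatter, so no order between them is claimed. Compound 4 `CC/C(=C(/c1ccc(/C=C/C(=O)O)cc1)c1ccc2[nH]nc(Cl)c2c1)c1ccccc1` differs from compound 3 in one place: a group of 10 heavy atoms (7 carbon, 2 nitrogen, 1 chlorine; one five-membered aromatic ring with 2 hetero atoms, one six-membered aromatic ring of carbon only) in place of a group of 9 heavy atoms (6 carbon, 3 nitrogen; one five-membered aromatic ring with 2 hetero atoms, one six-membered aromatic ring with 1 hetero atom), on a double-bonded chain carbon bound to an aromatic carbon and a double-bonded chain carbon. Among the measured compounds shown here, the only measured step, an at least 15-fold lower number from compound 1 to compound 2 (1.19 log units; beyond the scatter), concerns a different kind of group, so no measured step bears on this exchange of ring systems. Compound 4 is therefore expected to stay close to compound 3. The expected step is a 1.1-fold higher number from compound 3 to compound 4 (0.03 log units; within the scatter), not beyond the scatter. For compound 4 in this assay the estimate is 35 nM, with a range of 12 nM to 110 nM.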

Compound 4, half-maximal inhibitory concentration: 284 nM
Compound 4: the middle estimate sits 8.1-fold (0.91 log units) below what was measured, outside the stated range (above it).
By their numbers in this assay, from the lowest: compounds 3 and 2 (each within the scatter of the next); then compound 4. At a limit, above all of these: compound 1.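

In this assay, the group on this double-bonded chain carbon matters as well as the chain group: 3-chloro-1H-indazol-5-yl in place of the nitrogen-containing ring system gives an 8.6-fold higher number from compound 3 to compound 4 (0.93 log units; beyond the scatter), a step beyond the scatter. Among the compounds shown here, until now, the only measured step concerned the chain group, so this is the first reading on the ring system. No measurement shown gives a cause for this step.

The exchange changes the chlorine and the ring nitrogen together, so their shares remain unseparated. Going by these compounds, a bromine or a methyl in place of the chlorine remains open.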